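Sulfamate series: swapping the benzyl halide for a pyridyl

The source may report more compounds than this note shows. Statements on the series, on what has been measured and on what is new or still open speak of the compounds shown alone.

Of the compounds shown here, three have been measured in an assay on HEK293 cells for inhibition of Steryl-sulfatase (Homo sapiens), tested at 1 uM; on this read-out lower numbers stand for a weaker effect and higher numbers for a stronger effect at the one concentration tested. Compound 1 `CCN(Cc1ccc(Br)cc1)c1cccc(C(=O)N2CCc3ccc(OS(N)(=O)=O)cc3C2)c1` gives 84.5%, compound 2 `CCN(Cc1ccncc1)c1ccc(C(=O)N2CCc3ccc(OS(N)(=O)=O)cc3C2)cc1` gives 86.6% and compound 3 `CCN(Cc1ccc(F)cc1)c1ccc(C(=O)N2CCc3ccc(OS(N)(=O)=O)cc3C2)cc1` gives 91.2%. Compound 1 has the lowest of the three numbers, but its gaps to compound 2 and to compound 3 both lie within the scatter, so no order among them can be read.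

Compound 4 `CCN(Cc1cccnc1)c1cccc(C(=O)N2CCc3ccc(OS(N)(=O)=O)cc3C2)c1` has not been measured. Relative to compound 1 it carries pyridin-3-yl in place of 4-bromophenyl on a saturated chain carbon bound to a nitrogen on an aromatic ring.

Within the data shown here, the only measured step with a comparable exchange is a number 4.6 percentage points higher from compound 2 to compound 3 (within the scatter), which runs from a pyridyl to a halogenated phenyl and stays within the scatter. The step to compound 4 goes the other way, from a halogenated phenyl to a pyridyl, on the same saturated chain carbon. On that basis no step beyond the scatter is expected in this assay.

Compound 4 is therefore estimated at 82%, with a range from 70% to 92%, which means an expected step of a number 2.5 percentage points lower from compound 1 to compound 4 (within the scatter).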

Compound 4, a percentage reported as inhibition, at one concentration (the size of the read-out at that concentration, not a potency): 33.5%
Estimate against measurement, compound 4: 48.5 percentage points above; the whole stated range lies above it.
By their numbers in this assay, from the lowest: compound 4; then compounds 1, 2 and 3 (each within the scatter of the next).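

Notes on this position: in this assay, the exchange of 4-bromophenyl for pyridin-3-yl on a saturated chain carbon bound to a nitrogen on an aromatic ring gives a large loss (a number 51 percentage points lower from compound 1 to compound 4 (beyond the scatter)), so the read-out here depends strongly on which ring this carbon carries. The earlier exchange between pyridin-4-yl and 4-fluorophenyl (a number 4.6 percentage points higher from compound 2 to compound 3 (within the scatter)) gave no sign of this, but compound 2 and compound 3 differ from compound 1 and compound 4 in more than this one place, so that step could not speak for this pair. No available evidence accounts for the size of the loss.

Still open, going by these compounds, is whether the loss follows the departure of the bromine or the entry of the ring nitrogen. A plain phenyl or a 6-bromopyridin-3-yl on the same carbon would separate the two.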